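The compounds below may be only part of what the source reports. "The series", "measured", "known", "first", "only" and "open" are said of these compounds alone.

Three fluorophenyl compounds have so far been tested in a functional assay on 1A9 cells (Homo sapiens); a lower number here means that less compound is needed, a higher number that more compound is needed for the effect. Compound 1 `Oc1nc(-c2cccc(F)c2)nc2ccccc12` gives > 20 ug/mL, which is a limit and not a number. Compound 2 `COc1cc2nc(-c3ccccc3F)nc(O)c2cc1OC` gives > 20 ug/mL, also a limit. Compound 3 `COc1cc2nc(-c3cccc(F)c3)nc(O)c2cc1OC` gives > 20 ug/mL, again a limit. The whole record therefore comes down to the limit of > 20 ug/mL in this assay, at which 3 of the 3 values shown sit, and compound 2 has no readable number to stand on.

Compound 4 `COc1cc2nc(-c3ccc(F)cc3)nc(O)c2cc1OC` keeps the core of compound 2 and differs in one place: 4-fluorophenyl in place of 2-fluorophenyl on an aromatic carbon. In words, 4-fluorophenyl stands in place of 2-fluorophenyl on the aromatic carbon between two ring nitrogen atoms. For the measured compounds named here, the one measured step that bears on this change is a step that the two limits leave unreadable from compound 2 to compound 3, so it offers no size to carry over. With nothing but limits behind it, no step beyond the usual scatter is expected in this assay, and a further limit seems the likeliest result. The expected change is a step that the limit leaves unreadable from compound 2 to compound 4. For compound 4 the estimate is 25 ug/mL, with an expected range from 10 ug/mL to 40 ug/mL.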

Compound 4, concentration for half-maximal effect: 16 ug/mL
Compound 4: the middle estimate sits 1.6-fold (0.19 log units) above what was measured, and the stated range covers the measured number.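

For the compounds shown here, with compound 4, this position on the shared core gives the first readable number in this assay: compound 4 gives 16 ug/mL. Putting 4-fluorophenyl in place of 2-fluorophenyl gives an at least 1.2-fold lower number from compound 2 to compound 4 (0.09 log units; that floor lies within the scatter), and putting it in place of 3-fluorophenyl gives an at least 1.2-fold lower number from compound 3 to compound 4 (0.09 log units; that floor lies within the scatter), so a real gain from this change is neither shown nor ruled out. Only compound 4 has a true number, and the others still stand at one shared limit: the limit of > 20 ug/mL in this assay, at which 3 of the 4 values shown sit.

The compounds shown leave open how large the two steps really are, as compound 2 and compound 3 have no number of their own. They also leave open what would happen to the number if an amine or a carboxylic acid took the place of the fluorine on the phenyl ring.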